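Compound 4 against its measured neighbours

The source may report more compounds than this note shows. Statements on the series, on what has been measured and on what is new or still open speak of the compounds shown alone.

Of the compounds shown here, three of the shared core have been measured in an ADME assay on HepG2 2.2.15 cells (Homo sapiens) for cytotoxicity; a lower number here means that less compound is tolerated, a higher number that more compound is tolerated. Compound 1 `CS(=O)(=O)OCCc1c(OS(C)(=O)=O)nc2ccc(Cl)cc2c1-c1ccccc1Cl` gives 804000 nM. Compound 2 `OCCc1c(Cl)nc2ccc(Cl)cc2c1-c1ccccc1Cl` gives 42500 nM. For compound 3 `CC(C)(C)[Si](CCc1c(OS(=O)(=O)C(F)(F)F)nc2ccc(Cl)cc2c1-c1ccccc1Cl)(c1ccccc1)c1ccccc1` only a limit of the assay is recorded, > 1560000 nM. Compound 3 thus stands at the ceiling of the assay, which is where one of the three values sits, as shown by the limit of > 1560000 nM in this assay, at which 1 of the 3 values shown sits. Compound 4 `CC(C)(C)[Si](CCc1c(Nn2nnc3ccccc32)nc2ccc(Cl)cc2c1-c1ccccc1Cl)(c1ccccc1)c1ccccc1` is not yet measured. It differs from compound 3 in one place: a group of 10 heavy atoms (6 carbon, 4 nitrogen; one five-membered aromatic ring with 3 hetero atoms, one six-membered aromatic ring of carbon only) in place of a group of 8 heavy atoms (1 carbon, 3 oxygen, 3 fluorine, 1 sulfur; no ring), on an aromatic carbon. For the measured compounds named here, no measured pair of the three differs in a single place, so no measured step is available as a guide; the gap between compound 2 and compound 1 shows that changes to this core can move the read-out well beyond the scatter. The expected step is an at least 3.1-fold lower number from compound 3 to compound 4 (0.49 log units; beyond the scatter), in the direction of a less tolerated compound, with a fair chance that the assay again reports only its limit. The estimate for compound 4 is 500000 nM, within 100000 nM to 1560000 nM.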

Compound 4, half-maximal cytotoxic concentration: > 1250000 nM
Compound 4: only a limit was reported; the forecaster's own chance of this, stated with the estimate: 35%; middle value at least 2.5-fold (0.39 log units) away from the limit.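

For the compounds shown here, compound 3 and compound 4 are both recorded only as limits, so no step between them can be read. The compounds shown leave open where the half-maximal cytotoxic concentrations of the two lie, and how far the change on the aromatic carbon moves the read-out.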